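The compounds below may be only part of what the source reports. "The series", "measured", "known", "first", "only" and "open" are said of these compounds alone.

Measured so far:
Compound 1, `N#Cc1cnc(NC(=O)CCCOc2cccc(Cl)c2)s1`, gives 224 mL.min-1.g-1 in an ADME assay on microsomes from liver (Mus musculus) for metabolic stability, read by LC-MS, using NADPH, tested at 1 uM; on this read-out lower numbers stand for slow clearance and higher numbers for fast clearance.
Compound 2, `Cc1cnc(NC(=O)NCCOc2ccc(Cl)c(C)c2)s1`, in this assay reaches only the limit > 866 mL.min-1.g-1, a bound of the test rather than a number.
Compound 3, `Cc1cnc(NC(=O)CCCOc2cccc(Cl)n2)s1`, in this assay likewise reaches only the limit > 866 mL.min-1.g-1.

Among the compounds with values here, compound 1 thus holds the only number among the three; the other two values are the limit of > 866 mL.min-1.g-1 in this assay, at which 2 of the 3 values shown sit. Compound 4, `N#Cc1cnc(NC(=O)CCCOc2ccccc2)s1`, has not yet been measured. It differs from compound 1 in a single place: hydrogen in place of chloro on an aromatic carbon. Within the data shown here, no pair of measured compounds differs in just one place, so no measured step guides this change. In this assay the step is expected to be small, with no clear direction beyond the scatter. Compound 4 is estimated at 250 mL.min-1.g-1, within 110 mL.min-1.g-1 to 560 mL.min-1.g-1. This estimate means an expected step of a 1.1-fold higher number from compound 1 to compound 4 (0.05 log units; within the scatter).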

Compound 4, intrinsic clearance in microsomes in the Mus musculus assay: 114 mL.min-1.g-1
Compound 4: the middle estimate sits 2.2-fold (0.34 log units) above what was measured; low and high end bracket the measured number.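

In the Mus musculus assay, hydrogen in place of chloro on this aromatic carbon gives a 2.0-fold lower number from compound 1 to compound 4 (0.29 log units; within the scatter), the first single-place step available here, and this step does not separate the two compounds. In a physicochemical assay for solubility, read by nephelometry, in phosphate buffer, at pH 6.5 (a higher number here means a more soluble compound, a lower number a less soluble compound), compound 1 gives < 1600 nM, which is a limit of the assay and not a number. In the physicochemical assay compound 4 gives 1100 nM, so the step between the two cannot be read. Only chloro and hydrogen are shown at this place on the core of compound 1, so whether a methoxy group or an amine there would give a step beyond the scatter stays open.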